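The source may report more compounds than this note shows. Statements on the series, on what has been measured and on what is new or still open speak of the compounds shown alone.

Measured so far:
- compound 1, `CC(C(=O)NCc1ccc(C(F)(F)F)cc1N1CCC(Cc2ccc(F)cc2)CC1)c1ccc(NS(C)(=O)=O)c(F)c1`: 0.4 nM
- compound 2, `CC(C(=O)NCc1ccc(C(F)(F)F)cc1OCc1ccccc1)c1ccc(NS(C)(=O)=O)c(F)c1`: 0.9 nM

Both numbers come from an assay on CHO cells for antagonist activity at transient receptor potential cation channel subfamily V member 1 (Homo sapiens), read by FLIPR; on this read-out lower numbers stand for stronger inhibition and higher numbers for weaker inhibition. Compound 2 stands at the higher of the two numbers; compound 1 gives a lower number, and that gap lies beyond the usual scatter of repeated measurements. Compound 3, `CC(C(=O)NCc1ccc(C(F)(F)F)cc1-c1cccnc1)c1ccc(NS(C)(=O)=O)c(F)c1`, has not yet been measured. It differs from compound 2 in one place: pyridin-3-yl in place of benzyloxy on an aromatic carbon. Going by the values given here, no measured pair shows this kind of change, so the expectation rests on compound 2 alone, and a modest step toward a higher number is expected, a 3.3-fold higher number from compound 2 to compound 3 (0.52 log units; beyond the scatter). Compound 3 is expected to give about 3 nM, with a likely range from 0.8 nM to 12 nM.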

Compound 3, inhibition constant: 59.4 nM
The estimate for compound 3 lay 20-fold (1.30 log units) below the measured number; the whole stated range lies below it.
By their numbers in this assay, from the lowest: compound 1; then compound 2; then compound 3.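

Pyridin-3-yl in place of benzyloxy on this aromatic carbon gives a 66-fold higher number from compound 2 to compound 3 (1.82 log units; beyond the scatter) in this assay. This position, ortho to a large group, therefore does not accept every ring-bearing group equally, which compound 1 and compound 2 alone could not show. Nothing available here explains the loss of inhibition.

Going by these compounds, the ring nitrogen and the loss of the oxygen-and-methylene link changed together, so their separate contributions remain open. A phenyl or pyridin-3-ylmethoxy group on this carbon would tell them apart.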